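Aryl ether variation across a cytotoxicity-screened series

The compounds below may be only part of what the source reports. "The series", "measured", "known", "first", "only" and "open" are said of these compounds alone.

For the measured compounds named here, compound 1 `Cc1cn(C2CCN(Cc3cc(Oc4ccccc4)ccn3)CC2)c(=O)[nH]c1=O` is the only member with a measured result: in an ADME assay on MRC5 cells (Homo sapiens) for cytotoxicity, read by fluorescence and resazurin assay, with a stated time of 3 days (on this read-out higher numbers stand for weaker inhibition and lower numbers for stronger inhibition), compound 1 gives > 64000 nM, which is a limit of the assay and not a number (the limit of > 64000 nM in this assay, at which 1 of the 2 values shown sits). Compound 2 `Cc1cn(C2CCN(Cc3cccc(Oc4ccncc4)c3)CC2)c(=O)[nH]c1=O` has no reported result in this assay ("not determined" (no result reported)), so where it stands cannot be fixed. Compound 3 `Cc1cn(C2CCN(Cc3cccc(Oc4cc(Cl)cc(Cl)c4)c3)CC2)c(=O)[nH]c1=O` carries 3,5-dichlorophenyl in place of pyridin-4-yl on an oxygen on an aromatic ring. Going by the values given here, no measured step exists in the set, so no direction of change beyond the scatter can be given for this pair. Compound 3 is expected to give 64000 nM in this assay, within 15000 nM to 128000 nM.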

Compound 3, half-maximal inhibitory concentration: 6730 nM
For compound 3 the middle estimate is 9.5-fold (0.98 log units) above the measured one; measured number below the stated range.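

No step can be read between compound 2 and compound 3 in this assay, and compound 1 adds none. Nothing shown accounts for the value of compound 3, and what the 3,5-dichlorophenyl group contributes to it stays open.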